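Chloro for methoxy on the aryl ring of compound 2

This account rests on a few compounds, and the source may have more. Where it says the series, first, only, none or still open, it means among the compounds named here.

Of the compounds shown here, two have been measured in a functional assay on ACHN cells (Homo sapiens) for inhibition; a higher number here means a weaker inhibitor of growth, a lower number a stronger inhibitor of growth. Compound 1, `O=C(/C=C/c1cccc(O)c1)c1cccc(-n2cc(-c3ccc(Cl)cc3)[nH]c2=O)c1`, gives 1840 nM. Compound 2, `COc1ccc(-c2cn(-c3cccc(C(=O)/C=C/c4ccc(O)c(OC)c4)c3)c(=O)[nH]2)cc1`, gives 3400 nM, the higher of the two numbers; compound 1 is its nearest neighbour and the two values lie within the scatter of each other, so no order between them is claimed. Among the measured compounds shown here, no single-point step between measured compounds exists, and no pattern beyond these two can be drawn.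

Compound 3, `COc1cc(/C=C/C(=O)c2cccc(-n3cc(-c4ccc(Cl)cc4)[nH]c3=O)c2)ccc1O`, is the next member to be tested. It differs from compound 2 in one place: chloro in place of methoxy on an aromatic carbon. Compound 1 already carries this chloro group on the same ring, though with a different substitution on the hydroxyphenyl side, and its value of 1840 nM gives no sign that the chloro group moves the number far. The expected step is therefore a 1.5-fold lower number from compound 2 to compound 3 (0.17 log units; within the scatter) and is not expected to exceed the scatter. Compound 3 is expected to give about 2300 nM, with a range from 900 nM to 6000 nM.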

Compound 3, concentration for 50% growth inhibition: 2190 nM
For compound 3 the middle estimate is 1.1-fold (0.02 log units) above the measured one, and the stated range covers the measured number.
By their numbers in this assay, from the lowest: compounds 1, 3 and 2 (each within the scatter of the next).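

Notes on the series: the swap from 4-methoxyphenyl to 4-chlorophenyl can now be read directly in this assay (a 1.6-fold lower number from compound 2 to compound 3 (0.19 log units; within the scatter)). Before this, the two groups could be set side by side only across compounds that also differed at the other end, so this is the first evidence that, with everything else held constant, exchanging methoxy for chloro on this aromatic carbon gives no step beyond the scatter. The second step isolates the other end with the 4-chlorophenyl group held fixed, and 4-hydroxy-3-methoxyphenyl in place of 3-hydroxyphenyl likewise stays within the scatter (a 1.2-fold higher number from compound 1 to compound 3 (0.08 log units; within the scatter)), so neither of the two places varied here has yet produced a readable difference in this assay. No supporting data bear on these results.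

Whether this aromatic carbon is insensitive in general remains open, since only chloro and methoxy are shown there and an amine, a carboxylic acid or a longer chain in the same place could give a different picture. It is also open whether the hydroxyphenyl end would respond to a change larger than the one shown, such as an amine in place of the hydroxyl group.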